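Benzamide to Pyrazinecarboxamide on a Shared Quinoline-Free Core

This account rests on a few compounds, and the source may have more. Where it says the series, first, only, none or still open, it means among the compounds named here.

Measured so far:
compound 1, `COc1ccc(C(=O)NCCNc2nc3cc(C)cc(C)c3cc2C#N)cc1`: 3000 nM
compound 2, `Cc1cc(C)c2cc(C#N)c(NCCNC(=O)c3ccccc3)nc2c1`: "not active" (no number reported)
compound 3, `COc1ccc(C(=O)NCCNc2nc3cc(C)cc(C)c3cc2C#N)cc1OC`: 1500 nM

In an in vitro assay on FRT cells with Cystic fibrosis transmembrane conductance regulator variant F508del (Homo sapiens) as the target, read by fluorescence, with a stated time of 24 h, at 37 degrees C, in the presence of a further agent that is not named here (a lower number here means that less compound is needed, a higher number that more compound is needed for the effect), compound 1 gives 3000 nM and compound 3 gives 1500 nM; the step of a 2.0-fold lower number from compound 1 to compound 3 (0.30 log units; within the scatter) lies within the scatter. Compound 2 gives "not active" (no number reported) in this assay, so no number places it against the other two, and it stands apart as the unsubstituted benzamide without a value. Compound 4 `Cc1cc(C)c2cc(C#N)c(NCCNC(=O)c3cnccn3)nc2c1` differs from compound 2 by pyrazin-2-yl in place of phenyl on a carbonyl carbon. Within the data shown here, no measured step exchanges the phenyl ring for a heteroaryl ring, and the one step at hand touches the benzoyl region only within the scatter, so it gives no direction for this assay. Compound 4 is expected near 6000 nM, between 1500 nM and 25000 nM, with a real chance that, like compound 2, no number is reported.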

Compound 4, half-maximal effective concentration: 6700 nM
Beside the measured number, compound 4's estimate is 1.1-fold (0.05 log units) below it; low and high end bracket the measured number.
By their numbers in this assay, from the lowest: compounds 3 and 1 (each within the scatter of the next); then compound 4.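

In this assay, compound 4 gives a number where compound 2, which carries phenyl on the same carbonyl carbon, has none, so a ring with two hetero atoms is tolerated at this position. Against the methoxy-bearing rings, pyrazin-2-yl loses modest ground, with a 4.5-fold higher number from compound 3 to compound 4 (0.65 log units; beyond the scatter) and a 2.2-fold higher number from compound 1 to compound 4 (0.35 log units; beyond the scatter). Compound 2 has no number and its step to compound 4 cannot be read, and nothing measured here accounts for these shifts. From the compounds shown here alone, whether pyridin-2-yl on this carbonyl carbon would match compound 3 stays open. So does the effect of a longer chain between the amide nitrogen and the shared core.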